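A few compounds are considered here, and "the series" means these few. Any claim that something is new, unique, unknown or untested is made for them only; others in the source may bear on it.

Measured so far: compound 1 `COc1ccc(C(=O)Nc2cccc(-c3oc4cc(-c5ccc(F)cc5)ccc4c(=O)c3O)c2)cc1` gives 8420 nM in a functional assay on HepG2 cells (Homo sapiens) for antiproliferative activity, read by CCK-8 assay, with a stated time of 72 h; a higher number here means a weaker inhibitor, a lower number a stronger inhibitor; compound 2 `O=C(Nc1cccc(-c2oc3cc(-c4ccc(F)cc4)ccc3c(=O)c2O)c1)c1ccc(Br)cc1` gives 13900 nM.

Compound 2 stands highest of the two numbers; compound 1 is nearest, and the step of a 1.7-fold higher number from compound 1 to compound 2 (0.22 log units; within the scatter) lies within the scatter. Compound 3 `Cc1cccc(C(=O)Nc2cccc(-c3oc4cc(-c5ccc(F)cc5)ccc4c(=O)c3O)c2)c1` differs by 3-methylphenyl in place of 4-bromophenyl on a carbonyl carbon. Among the compounds with values here, the only measured step that bears on it is the earlier swap on the same ring, a 1.7-fold higher number from compound 1 to compound 2 (0.22 log units; within the scatter), which stayed within the scatter, so the expected step of a 1.4-fold lower number from compound 2 to compound 3 (0.14 log units; within the scatter) is none beyond the scatter. Compound 3 is therefore estimated at 10000 nM, with a range from 4000 nM to 25000 nM.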

Compound 3, half-maximal inhibitory concentration: 13500 nM
For compound 3 the middle estimate is 1.4-fold (0.13 log units) below the measured one, and the stated range covers the measured number.
By their numbers in this assay, from the lowest: compounds 1, 3 and 2 (each within the scatter of the next).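

In this assay the swap of 4-bromophenyl for 3-methylphenyl on the carbonyl carbon gives a 1.0-fold lower number from compound 2 to compound 3 (0.01 log units; within the scatter) and the swap of 4-methoxyphenyl for 3-methylphenyl gives a 1.6-fold higher number from compound 1 to compound 3 (0.21 log units; within the scatter) with no separation from the other two compounds. All three compounds now lie within the scatter of one another, even with a different group name and ring numbering at this position. No measurement here offers an explanation for this flat result.

From the compounds shown here alone, whether an amine or a carboxylic acid on this phenyl ring would give a step beyond the scatter stays open. Changes elsewhere on the shared core also stay open.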